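Compound 3 to compound 4: swapping ethoxy for 2-methoxyethyl

This account rests on a few compounds, and the source may have more. Where it says the series, first, only, none or still open, it means among the compounds named here.

- compound 1 `Cc1cc(Nc2ccc(C(F)(F)F)cc2)n2nc(CCO)nc2n1`: 67%
- compound 2 `COCCc1nc2nc(C)cc(Nc3ccc(S(F)(F)(F)(F)F)cc3)n2n1`: 87.7%
- compound 3 `CCOc1nc2nc(C)cc(Nc3ccc(C(F)(F)F)cc3)n2n1`: 92.4%

In an ADME assay on a cell-free system (plasma, Homo sapiens) for protein binding, compound 3 gives 92.4%, within the scatter of compound 2 and well apart from compound 1. Compound 4 `COCCc1nc2nc(C)cc(Nc3ccc(C(F)(F)F)cc3)n2n1` differs from it as follows: 2-methoxyethyl in place of ethoxy on an aromatic carbon. That is 2-methoxyethyl in place of ethoxy on an aromatic carbon. Among the compounds with values here, no measured step makes this exact swap. The closest is a 4.3-fold lower unbound fraction from compound 1 to compound 3 (0.64 log units; beyond the scatter), with ethoxy in place of 2-hydroxyethyl. Compound 2 carries the same 2-methoxyethyl but differs elsewhere, and its 87.7% suggests that binding stays high. A smaller step in the opposite direction is therefore expected: a 2.0-fold higher unbound fraction from compound 3 to compound 4 (0.30 log units; within the scatter). The estimate for compound 4 is 85%, with an expected range of 74% to 92%.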

Compound 4, plasma protein binding: 73.7%
The estimate for compound 4 lay 1.8-fold (0.24 log units) (unbound fraction) below the measured number; the measured number lies below the stated range.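

In this assay the group at this position carries real weight: there is a 3.5-fold higher unbound fraction from compound 3 to compound 4 (0.54 log units; beyond the scatter) for this one change, so ethoxy and 2-methoxyethyl are not interchangeable here. The high binding of compound 2 does not come from its 2-methoxyethyl alone, as trifluoromethyl in place of pentafluorosulfanyl gives a 2.1-fold higher unbound fraction from compound 2 to compound 4 (0.33 log units; beyond the scatter) at the other place in the molecule. Methyl in place of hydrogen on the chain's oxygen gives only a 1.3-fold lower unbound fraction from compound 1 to compound 4 (0.10 log units; within the scatter) and leaves ethoxy apart from both chains. Whether an amine or a longer chain here would behave like ethoxy or like 2-methoxyethyl stays open, and no available evidence accounts for the difference between these groups.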